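A few compounds are considered here, and "the series" means these few. Any claim that something is new, unique, unknown or untested is made for them only; others in the source may bear on it.

Compound 1 `CCCSC[C@H]1OC(n2cnc3c(N)ncnc32)[C@H](O)[C@@H]1O` - 1000000 nM
Compound 2 `Nc1ncnc2c1ncn2C1O[C@H](CSCCCF)[C@@H](O)[C@H]1O` - 600000 nM

In a functional assay on L1210 cells (Mus musculus), with a stated time of 48 h (a higher number here means a weaker inhibitor, a lower number a stronger inhibitor), compound 2 gives 600000 nM and sits within the scatter of compound 1. In compound 3 `Nc1ncnc2c1ncn2C1O[C@H](CSCCO)[C@@H](O)[C@H]1O` the change from compound 2 is hydroxy in place of fluoromethyl on a saturated chain carbon, two bonds along the chain from a sulfur and, in words, hydroxy in place of fluoromethyl on a saturated chain carbon, two bonds along the chain from a sulfur. Among the measured compounds shown here, only a 1.7-fold lower number from compound 1 to compound 2 (0.22 log units; within the scatter) bears on this, and it is a change of fluoro in place of hydrogen, since no compound with a hydroxy has been measured. No step beyond the scatter is therefore expected in this assay. The estimated step is no change at the digits printed from compound 2 to compound 3 (within the scatter) in size. Compound 3 is expected at 600000 nM with an estimated range from 200000 nM to 1500000 nM in this read-out.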

Compound 3, half-maximal inhibitory concentration: 1000000 nM
The estimate for compound 3 lay 1.7-fold (0.22 log units) below the measured number, within the range that was stated.
By their numbers in this assay, from the lowest: compounds 2, 1 and 3 (each within the scatter of the next).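

In this assay, hydroxy in place of fluoromethyl on this saturated chain carbon, two bonds along the chain from a sulfur, gives a 1.7-fold higher number from compound 2 to compound 3 (0.22 log units; within the scatter), and hydroxy in place of methyl gives no change at the digits printed from compound 1 to compound 3 (within the scatter). Hydroxy is the first group here to bring a hydrogen-bond donor and a hydrogen-bond acceptor to this place, yet both steps stay within the scatter. No measurement at hand offers an explanation for this result. The compounds shown leave open whether an amine, a carboxylic acid or a longer chain at this place would give a step beyond the scatter.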